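A few compounds are considered here, and "the series" means these few. Any claim that something is new, unique, unknown or untested is made for them only; others in the source may bear on it.

Measured compounds:
compound 1 `Cc1cc(O)c(C(=O)/C=C/c2ccccc2Cl)c(-c2ccccc2)c1C(=O)/C=C/c1ccccc1Cl` gives "not active" (no number reported) in a functional assay on HeLa cells (Homo sapiens) for cytotoxicity, read by MTT assay, with a stated time of 24 h; a lower number here means a stronger inhibitor, a higher number a weaker inhibitor
compound 2 `COc1ccc(/C=C/C(=O)c2c(C)cc(O)c(C(=O)/C=C/c3ccc(OC)cc3)c2-c2ccccc2)cc1` gives "not active" (no number reported) in this assay
compound 3 `Cc1cc(O)c(C(=O)/C=C/c2ccc(Cl)cc2)c(-c2ccc(Br)cc2)c1C(=O)/C=C/c1ccc(Cl)cc1` gives 32000 nM in this assay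

The three compounds share the same core and differ only in the groups hanging from it. Compound 2 has no single number in this assay: the result reads "not active" (no number reported), and compound 1 is the other entry that likewise has no number. Within the data shown here, only compound 3 returns a value, and it is a weak one; compound 3 differs from compound 2 in two places at once, so no single step joins the two.

Compound 4 `COc1ccc(/C=C/C(=O)c2c(C)cc(O)c(C(=O)/C=C/c3ccc(OC)cc3)c2-c2ccc(Br)cc2)cc1` is the one-place relative of compound 2: the change is bromo in place of hydrogen on an aromatic carbon, the phenyl becoming a 4-bromophenyl. Among the measured compounds shown here, no measured pair isolates this change, so the size of the step can only be guessed. Because compound 3, which also carries the 4-bromophenyl, reaches 32000 nM, a weak number for compound 4 seems possible, though it may again come back without one.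

Compound 4 is expected to give about 50000 nM, between 15000 nM and 200000 nM.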

Compound 4, half-maximal inhibitory concentration: "not active" (no number reported)
Compound 4: no number reported; there is nothing to compare the estimate with.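

Compound 2 and compound 4 both return no number in this assay and so the change from hydrogen to bromo cannot be sized as a step. The compounds shown leave open what this change does on its own. No evidence bears on this result.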